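The compounds below may be only part of what the source reports. "The series", "measured", "known", "first", "only" and "open" are said of these compounds alone.

Compound 1 `Cc1ccccc1N1CCN(C(=S)SCc2ccc3nc(N)nc(N)c3c2)CC1`: 11800 nM
Compound 2 `Nc1nc(N)c2cc(CSC(=S)N3CCN(c4ccc(Cl)cc4)CC3)ccc2n1`: 7380 nM
Compound 3 `Nc1nc(N)c2cc(CSC(=S)N3CCN(c4ccccc4Cl)CC3)ccc2n1`: 5490 nM

In a functional assay on HCT-116 cells (Homo sapiens) for antiproliferative activity, read by MTT assay, with a stated time of 72 h (a lower number here means a stronger inhibitor, a higher number a weaker inhibitor), compound 3 gives 5490 nM. It cannot be told apart from compound 2, with a 1.3-fold lower number from compound 2 to compound 3 (0.13 log units; within the scatter), but it stands modestly clear of compound 1, with a 2.1-fold lower number from compound 1 to compound 3 (0.33 log units; beyond the scatter). Compound 4 `Nc1nc(N)c2cc(CSC(=S)N3CCN(c4ccc(F)cc4F)CC3)ccc2n1` carries a single change: 2,4-difluorophenyl in place of 2-chlorophenyl on an amine nitrogen in a ring. Going by the values given here, no measured compound carries fluorine, so no step speaks to this change directly. The nearest evidence is the other changes to the group at this place: a 1.6-fold lower number from compound 1 to compound 2 (0.20 log units; within the scatter) and the two steps to compound 3 already given. All are small, and only one goes beyond the scatter, and then only modestly. A step within the scatter in this assay is therefore expected, with no firm direction. The expected step is a 1.2-fold higher number from compound 3 to compound 4 (0.07 log units; within the scatter). Compound 4 is estimated at 6500 nM, with an expected range from 3000 nM to 13000 nM.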

Compound 4, half-maximal inhibitory concentration: 5150 nM
The estimate for compound 4 lay 1.3-fold (0.10 log units) above the measured number; measured number inside the range.
By their numbers in this assay, from the lowest: compounds 4, 3, 2 and 1 (each within the scatter of the next, the first and the last beyond it).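

In this assay the 2,4-difluorophenyl group, the only fluorine-bearing group shown at this place on the amine nitrogen, cannot be told apart from 2-chlorophenyl, with a 1.1-fold lower number from compound 3 to compound 4 (0.03 log units; within the scatter) within the scatter, or from 4-chlorophenyl, with a 1.4-fold lower number from compound 2 to compound 4 (0.16 log units; within the scatter) likewise. It stands modestly clear only of 2-methylphenyl, with a 2.3-fold lower number from compound 1 to compound 4 (0.36 log units; beyond the scatter) as the largest step in the set, so swapping one substituted phenyl for another has moved the number little across all four compounds. Nothing available explains why these groups give such similar numbers.

Going by these compounds, it remains open whether an unsubstituted phenyl, a benzyl group or a pyridine ring on this nitrogen would leave this narrow band. Also open, on these data alone, is whether a methoxy or trifluoromethyl group on the phenyl ring would do so.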